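The source may hold more compounds than are shown below. What is called first, only, known or untested is meant among the compounds shown, and "the series" means these compounds.

Working notes on the series.

Compound 1 `CCC(C)(C)/N=c1\c(O)c(O)\c1=N/Cc1ccc(Cl)cc1Cl` gives 210 nM in a functional assay for inhibition, with Rattus norvegicus as the target; a lower number here means a stronger inhibitor, a higher number a weaker inhibitor. Compound 2 `CC[C@H](C)/N=c1\c(O)c(O)\c1=N/Cc1ccc(C#N)cc1` gives 2200 nM in this assay; compound 2 differs from compound 1 in two places at once, so its two values are noted without a step. Compound 3 `CCC(C)(C)/N=c1\c(O)c(O)\c1=N/Cc1ccc(C#N)cc1Cl` gives 130 nM in this assay, the lowest of the three numbers recorded; the gap to compound 1 is within the scatter, the gap to compound 2 is beyond it. Among the measured compounds shown here, the one single-point step recorded, a 1.6-fold lower number from compound 1 to compound 3 (0.21 log units; within the scatter), changed nothing beyond the scatter.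

The next compound, compound 4 `CCC(C)(C)/N=c1\c(O)c(O)\c1=N/Cc1ccc(C#N)cc1`, follows from compound 3 by hydrogen in place of chloro on an aromatic carbon. For the measured compounds named here, no measured step covers this change: the recorded step from compound 1 to compound 3 concerns the cyano for chloro exchange, not the loss of a chloro for hydrogen. Going by the values given here, the only measured compound lacking that chloro is compound 2, which gives 2200 nM, but compound 2 also carries a different group on the core, so its value is a weak guide. In this assay compound 4 is therefore expected to give a higher number than compound 3, by a step of a 3.8-fold higher number from compound 3 to compound 4 (0.59 log units; beyond the scatter), with wide uncertainty. The estimate for compound 4 in this assay is 500 nM, within a range of 150 nM to 2000 nM.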

Compound 4, half-maximal inhibitory concentration: 1100 nM
Compound 4: the middle estimate sits 2.2-fold (0.34 log units) below what was measured; the measured number falls inside the stated range.
By their numbers in this assay, from the lowest: compounds 3 and 1 (each within the scatter of the next); then compounds 4 and 2 (each within the scatter of the next).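

Among the compounds shown here, at this aromatic carbon, ortho to a large group and meta to a cyano group, chloro gives way to hydrogen with an 8.5-fold higher number from compound 3 to compound 4 (0.93 log units; beyond the scatter) in this assay, the first single-point step to lie beyond the scatter, whereas the earlier cyano for chloro exchange, a 1.6-fold lower number from compound 1 to compound 3 (0.21 log units; within the scatter), did not. The change on the double-bonded nitrogen, read without this chloro present, is a 2.0-fold lower number from compound 2 to compound 4 (0.30 log units; within the scatter), so 1,1-dimethylpropyl in place of sec-butyl shows no difference beyond the scatter in this pair. Nothing at hand bears on why the chloro counts for so much here.

For the compounds shown here, whether chloro is the only group that holds the number down at this carbon stays open, since fluoro, methyl or methoxy there would separate a need for chloro itself from a need for any group larger than hydrogen. Also open, as far as these compounds go, is whether the loss of this chloro costs as much with a chloro rather than a cyano group on the other ring position, and whether a longer chain on the double-bonded nitrogen would behave as sec-butyl and 1,1-dimethylpropyl do.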